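A Branched Chain Replaces a Straight One

This account rests on a few compounds, and the source may have more. Where it says the series, first, only, none or still open, it means among the compounds named here.

Compound 1 `CCCCCNc1oc2c(C)ncc(CO)c2c1Nc1ccccn1` sits at the lower of the two numbers measured in a functional assay on HEK293 cells for agonist activity at Toll-like receptor 8 (Homo sapiens), read by reporter gene assay (a lower number here means that less compound is needed, a higher number that more compound is needed for the effect), giving 5810 nM. Compound 2 `CCCCNc1oc2c(C)ncc(CO)c2c1Nc1ccccn1` gives 9380 nM, and the step of a 1.6-fold higher number from compound 1 to compound 2 (0.21 log units; within the scatter) stays inside the scatter. Compound 3 `Cc1ncc(CO)c2c(Nc3ccccn3)c(N)oc12` carries no chain at all, and in this assay compound 3 gives "not active" (no number reported), so no number exists for it. Compound 4 `Cc1ncc(CO)c2c(Nc3ccccn3)c(NC(C)(C)C)oc12` differs from compound 1 as follows: tert-butyl in place of pentyl on a nitrogen on an aromatic ring. Among the compounds with values here, the only measured step that bears on this change, shortening pentyl by one carbon, was small, while removing the chain entirely removed the activity. A modest rise is therefore expected for compound 4 in this assay, with a 2.6-fold higher number from compound 1 to compound 4 (0.41 log units; beyond the scatter), giving an estimate of 15000 nM within a range from 5000 nM to 50000 nM.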

Compound 4, half-maximal effective concentration: "not active" (no number reported)
Nothing numeric was reported for compound 4, so the estimate cannot be set against anything.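

Compound 4, like compound 3, has no reported number, so no step can be read from compound 1 to compound 4. No evidence here accounts for this result. The compounds shown leave open which other chains on the nitrogen would keep activity.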